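Benzyl sulfonyl analogue in the antiproliferative series

This account rests on a few compounds, and the source may have more. Where it says the series, first, only, none or still open, it means among the compounds named here.

Compound 1 `COc1ccc(-c2c(Br)c(=O)c3c(OC)cc(OC)cc3n2S(=O)(=O)c2ccc(OC)cc2)cc1` gives 49700 nM in an ADME assay on BJ cells (Homo sapiens) for antiproliferative activity, with a stated time of 72 h; a higher number here means that more compound is needed for the effect, a lower number that less compound is needed. Compound 2 `COc1ccc(-c2cc(=O)c3c(OC)cc(OC)cc3n2S(=O)(=O)c2ccc(C#N)cc2)cc1` reaches only a limit in this assay, > 17200 nM, which is the limit of > 17200 nM in this assay, at which 1 of the 2 values shown sits. Compound 3 `COc1ccc(-c2cc(=O)c3c(OC)cc(OC)cc3n2S(=O)(=O)Cc2ccccc2)cc1` carries the change (benzyl in place of 4-cyanophenyl on a sulfonyl sulfur); the benzyl group enters where the 4-cyanophenyl group leaves, on the sulfonyl sulfur. For the measured compounds named here, no measured step exists for this kind of change, and compound 2 itself offers no number to step from. The step expected for compound 3 in this assay is a step that the limit leaves unreadable from compound 2 to compound 3, not beyond the scatter. Compound 3 is expected to show 30000 nM, with a range from 10000 nM to 100000 nM.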

Compound 3, half-maximal effective concentration: > 34400 nM
Compound 3 gave a limit, no number; the forecaster's own chance of this, stated with the estimate: 55%; middle value at least 1.1-fold (0.05 log units) away from the limit.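

No step can be read from compound 2 to compound 3 in this assay: both results are limits, not numbers. The compounds shown leave open how benzyl and 4-cyanophenyl on a sulfonyl sulfur compare in this assay.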